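From 3,4-dichlorophenyl to 3,5-dichlorophenyl: an expected small step

The compounds below may be only part of what the source reports. "The series", "measured", "known", "first", "only" and "open" are said of these compounds alone.

Measured so far in a functional assay on MCF7 cells (Homo sapiens) for cytotoxicity, read by MTT assay, with a stated time of 72 h (on this read-out higher numbers stand for weaker inhibition and lower numbers for stronger inhibition), are two compounds:
- Compound 1 `COc1cccc(/C=C2\CCC/C(=C\c3ccc(Br)cc3)C2=O)c1OC` gives 13800 nM
- Compound 2 `COc1cccc(/C=C2\CCC/C(=C\c3ccc(Cl)c(Cl)c3)C2=O)c1OC` gives 9000 nM

For the measured compounds named here, compound 2 stands within the usual scatter of the only other measured compound, so these two numbers cannot be put in order. Going by the values given here, the one measured step is a 1.5-fold lower number from compound 1 to compound 2 (0.19 log units; within the scatter) and it exchanges 4-bromophenyl for 3,4-dichlorophenyl at the same place in the molecule.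

Compound 3 `COc1cccc(/C=C2\CCC/C(=C\c3cc(Cl)cc(Cl)c3)C2=O)c1OC` has not been measured yet. Its difference from compound 2 is 3,5-dichlorophenyl in place of 3,4-dichlorophenyl on a double-bonded chain carbon bound to a double-bonded ring carbon and in plain words this puts 3,5-dichlorophenyl in place of 3,4-dichlorophenyl on a double-bonded chain carbon bound to a double-bonded ring carbon. The two have the same atoms, joined differently.

Among the compounds with values here, no measured pair shows this exact change, and the single step at this place stayed within the scatter. A step beyond the scatter is therefore not expected in this assay and no direction can be favoured. The expected change is a 1.1-fold higher number from compound 2 to compound 3 (0.05 log units; within the scatter) and it is only an estimate. For compound 3 the estimated value is 10000 nM with an expected range from 4500 nM to 22000 nM in this read-out.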

Compound 3, half-maximal inhibitory concentration: 4300 nM
Estimate against measurement, compound 3: 2.3-fold (0.37 log units) above; the measured number lies below the stated range.
By their numbers in this assay, from the lowest: compound 3; then compounds 2 and 1 (each within the scatter of the next).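

In this assay, rearranging the same two chlorine atoms on the ring gives a 2.1-fold lower number from compound 2 to compound 3 (0.32 log units; beyond the scatter), so this position responds to where the chlorines sit and not only to which atoms are present. Set against the 4-bromophenyl group, the 3,5-dichlorophenyl group gives a 3.2-fold lower number from compound 1 to compound 3 (0.51 log units; beyond the scatter), which makes compound 3 the only one of the three separated from both others by steps beyond the scatter, whereas compounds 1 and 2 could not be put in order. For the compounds shown here, these modest steps are the first at this place to pass the scatter, and no measurement is available that would explain them.

From the compounds shown here alone, all three compounds carry only halogens on this phenyl ring, so it remains open whether the change in the number depends on chlorine itself or whether a phenyl ring bearing an amine, a carboxylic acid or a methoxy group in its place would fit the same trend. All three also share one core, and this assay is the only read-out shown, so it is unknown whether the difference between the two dichlorophenyl groups holds on another core or in other cells.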